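Ether linker returns in place of direct aryl

A few compounds are considered here, and "the series" means these few. Any claim that something is new, unique, unknown or untested is made for them only; others in the source may bear on it.

In a functional assay on HEK293 cells for agonist activity at G-protein coupled receptor 39 (Homo sapiens), read by scintillation proximity assay and inositol phosphate accumulation, with a stated time of 75 min (on this read-out lower numbers stand for an effect already at smaller amounts and higher numbers for an effect only at larger amounts of compound), compound 2 `Cc1nn(-c2ncnc3nc[nH]c23)c2c1C(c1ccc(OC(C)C)cc1)CC(=O)N2` gives 2700 nM, the higher of the two numbers here, while compound 1 `Cc1nn(-c2ncnc3nc[nH]c23)c2c1C(OCc1ccccc1C#N)CC(=O)N2` gives 127 nM. Among the compounds with values here, the one measured step, a 21-fold higher number from compound 1 to compound 2 (1.33 log units; beyond the scatter), is the replacement of an ether-linked group by a directly attached aryl. Compound 3 `Cc1nn(-c2ncnc3nc[nH]c23)c2c1C(OCCn1nccc1C)CC(=O)N2` carries a group of 9 heavy atoms (6 carbon, 2 nitrogen, 1 oxygen; one five-membered aromatic ring with 2 hetero atoms) in place of a group of 10 heavy atoms (9 carbon, 1 oxygen; one six-membered aromatic ring of carbon only), on a saturated ring carbon, restoring an ether oxygen at that saturated ring carbon. Because of a 21-fold higher number from compound 1 to compound 2 (1.33 log units; beyond the scatter), going back to an ether-linked group should bring the number down. For compound 3 the expected step is a 9.0-fold lower number from compound 2 to compound 3 (0.95 log units; beyond the scatter). Compound 3 is expected at 300 nM, in a range from 60 nM to 1500 nM.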

Compound 3, half-maximal effective concentration: 1620 nM
Estimate against measurement, compound 3: 5.4-fold (0.73 log units) below, outside the stated range (above it).
By their numbers in this assay, from the lowest: compound 1; then compounds 3 and 2 (each within the scatter of the next).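

At this saturated ring carbon, an ether oxygen alone does not set the number: a 1.7-fold lower number from compound 2 to compound 3 (0.22 log units; within the scatter) leaves the ether-linked group of compound 3 and the 4-isopropoxyphenyl of compound 2 indistinguishable. Among the ether-linked groups the outcome depends on what lies beyond the oxygen, with a 13-fold higher number from compound 1 to compound 3 (1.11 log units; beyond the scatter) for (5-methyl-1H-pyrazol-1-yl)methyl in place of 2-cyanophenyl. No supporting data bear on the origin of either step. Still open, on these data alone, is whether a plain benzyl group, without the nitrile, stays close to compound 1, and how an amine or a carboxylic acid on the ether chain would read.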